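Swapping 4-chlorophenyl for 3-hydroxyphenyl at the assay limit

A few compounds are considered here, and "the series" means these few. Any claim that something is new, unique, unknown or untested is made for them only; others in the source may bear on it.

In a functional assay on HCT-116 cells (Homo sapiens) for inhibition, read by MTT assay, with a stated time of 48 h (a lower number here means a stronger inhibitor, a higher number a weaker inhibitor), compound 3 (`COc1cc(NCc2ccc(Cl)cc2)cc(OC)c1OC`) gives > 80000 nM, which is a limit and not a number. Compound 1 (`COc1cc(NCc2ccccc2)cc(OC)c1OC`) gives > 80000 nM, also a limit. This is the limit of > 80000 nM in this assay, at which 2 of the 3 values shown sit. Among the compounds with values here, the only measured step here is a step that the two limits leave unreadable from compound 1 to compound 3, so it offers no size to carry forward. Compound 2 (`COCC(=O)N(Cc1ccc(OC)c(O)c1)c1cc(OC)c(OC)c(OC)c1`) gives a true number, 230 nM, but it differs from compound 4 in more than one place. Compound 4 (`COc1cc(NCc2cccc(O)c2)cc(OC)c1OC`) carries 3-hydroxyphenyl in place of 4-chlorophenyl on a saturated chain carbon bound to a nitrogen on an aromatic ring. With only the limit of compound 3 at > 80000 nM to start from, no large change is expected, and the expected step is an at least 1.1-fold lower number from compound 3 to compound 4 (0.05 log units; that floor lies within the scatter). For compound 4 the estimate is 70000 nM, with an expected range from 25000 nM to 150000 nM.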

Compound 4, half-maximal inhibitory concentration: 67700 nM
Compound 4: the middle estimate sits 1.0-fold (0.01 log units) above what was measured; the measured number falls inside the stated range.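

Unlike compound 1 and compound 3, compound 4 gives a true number and not a limit, so 3-hydroxyphenyl at this saturated chain carbon is the first change here that can be read on a scale: the limit of > 80000 nM in this assay, at which 2 of the 4 values shown sit.

The steps are an at least 1.1-fold lower number from compound 3 to compound 4 (0.07 log units; that floor lies within the scatter) and an at least 1.1-fold lower number from compound 1 to compound 4 (0.07 log units; that floor lies within the scatter). From the compounds shown here alone, each is only a floor, so the real size of either change stays unknown.

Open, going by these compounds, is whether an amine or a carboxylic acid in place of the hydroxy of 3-hydroxyphenyl would give a clearly lower number.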